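Swapping isopropyl for methyl on a weak melanoma cell inhibitor

The source may report more compounds than this note shows. Statements on the series, on what has been measured and on what is new or still open speak of the compounds shown alone.

Of the compounds shown here, two sharing one core have been tested in a functional assay on B16-F10 cells (Mus musculus) for inhibition, read by MTT assay, with a stated time of 72 h; on this read-out higher numbers stand for weaker inhibition and lower numbers for stronger inhibition. Compound 1 `CC(C)c1ccc(-c2nc(SCc3cn(CC(=O)NC(=O)Nc4ccccn4)nn3)nc(Nc3ccccc3Cl)c2C#N)cc1` gives 6790 nM. Compound 2 `COc1ccccc1Nc1nc(SCc2cn(CC(=O)NC(=O)Nc3ccccn3)nn2)nc(-c2ccc(C(C)C)cc2)c1C#N` gives 34600 nM, which is the higher of the two numbers, so compound 2 is the weaker inhibitor of the pair. Within the data shown here, the single step between them, a 5.1-fold higher number from compound 1 to compound 2 (0.71 log units; beyond the scatter), concerns the aromatic ring that carries the chloro or methoxy group.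

Compound 3 `COc1ccccc1Nc1nc(SCc2cn(CC(=O)NC(=O)Nc3ccccn3)nn2)nc(-c2ccc(C)cc2)c1C#N` has not yet been measured. Among the measured compounds shown here, it differs from compound 2 by methyl in place of isopropyl on an aromatic carbon, a change that sits on a different ring from the one altered between compound 1 and compound 2. For the measured compounds named here, no measured step therefore bears on this change, and the data give no ground to expect movement in either direction. The expectation is that compound 3 will stay close to compound 2, with a step of a 1.2-fold higher number from compound 2 to compound 3 (0.06 log units; within the scatter) in this assay that lies within the scatter. The estimated value for compound 3 is 40000 nM, with a range from 12000 nM to 130000 nM.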

Compound 3, half-maximal inhibitory concentration: 8580 nM
Compound 3: the middle estimate sits 4.7-fold (0.67 log units) above what was measured, outside the stated range (below it).
By their numbers in this assay, from the lowest: compounds 1 and 3 (each within the scatter of the next); then compound 2.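

In this assay, the group on the aromatic ring, para to a large group, does affect the read-out: going from 4-isopropylphenyl to 4-methylphenyl gives a 4.0-fold lower number from compound 2 to compound 3 (0.61 log units; beyond the scatter). Here the smaller group, methyl with 1 heavy atom in place of isopropyl with 3, goes with stronger inhibition, which the earlier compounds could not show because they both carry isopropyl. No measurement here explains this shift.

From the compounds shown here alone, two groups at this position cannot define a trend, so it remains open whether a hydrogen, an ethyl group, a longer chain, an amine or a carboxylic acid there would continue the shift, reverse it or leave the number unchanged. Going by these compounds, it is also open whether the same swap from isopropyl to methyl would give a similar step with chloro rather than methoxy on the other ring, which would show whether the two positions act independently.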